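The source may hold more compounds than are shown below. What is called first, only, known or untested is meant among the compounds shown, and "the series" means these compounds.

Measured in a physicochemical assay for solubility; a higher number here means a more soluble compound, a lower number a less soluble compound:
- compound 1 `O=C(c1cccnc1)N1CCC(NS(=O)(=O)c2cc(S(=O)(=O)c3ccccc3)ccc2C(F)(F)F)CC1`: 50000 nM
- compound 2 `O=C(O)CCCC(=O)N1CCC(NS(=O)(=O)c2cc(S(=O)(=O)c3ccccc3)ccc2C(F)(F)F)CC1`: 50000 nM
- compound 3 `CC(C)(C)OC(=O)N1CCC[C@H]1C(=O)N1CCC(NS(=O)(=O)c2cc(S(=O)(=O)c3ccccc3)ccc2C(F)(F)F)CC1`: 25000 nM

Compound 3 sits within the scatter of both others, with a 2.0-fold lower number from compound 1 to compound 3 (0.30 log units; within the scatter) and a 2.0-fold lower number from compound 2 to compound 3 (0.30 log units; within the scatter). Compound 4 `CC(C)(C)OC(=O)N1CC[C@@H](C(=O)N2CCC(NS(=O)(=O)c3cc(S(=O)(=O)c4ccccc4)ccc3C(F)(F)F)CC2)C1` has the same atoms joined differently, with 1-(tert-butoxycarbonyl)pyrrolidin-3-yl in place of 1-(tert-butoxycarbonyl)pyrrolidin-2-yl on a carbonyl carbon. For the measured compounds named here, no measured step makes this exact swap. The nearest evidence is those two steps to compound 3, along with no change at the digits printed from compound 1 to compound 2 (within the scatter), which also exchanges the group on that carbonyl carbon. None of them exceeds the scatter, so the expected step is a 1.2-fold higher number from compound 3 to compound 4 (0.08 log units; within the scatter), with nothing beyond the scatter anticipated. For compound 4 the estimated value in this assay is 30000 nM, with an expected range of 14000 nM to 60000 nM.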

Compound 4, solubility: 12500 nM
The estimate for compound 4 lay 2.4-fold (0.38 log units) above the measured number; the measured number lies below the stated range.
By their numbers in this assay, from the lowest: compounds 4, 3, 1 and 2 (each within the scatter of the next, the first and the last beyond it).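

In this assay, moving the attachment from 1-(tert-butoxycarbonyl)pyrrolidin-2-yl to 1-(tert-butoxycarbonyl)pyrrolidin-3-yl gives a 2.0-fold lower number from compound 3 to compound 4 (0.30 log units; within the scatter). Even so, this group gives the first modest steps beyond the scatter on this carbonyl carbon, with a 4.0-fold lower number from compound 1 to compound 4 (0.60 log units; beyond the scatter) and a 4.0-fold lower number from compound 2 to compound 4 (0.60 log units; beyond the scatter). No measurement shown here accounts for these steps. The compounds shown leave open whether a free secondary amine in place of the tert-butoxycarbonyl-bearing nitrogen would change the number at this position. They also leave open how a longer carboxylic acid chain on that carbonyl carbon would compare.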